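A ring swap on compound 2

A few compounds are considered here, and "the series" means these few. Any claim that something is new, unique, unknown or untested is made for them only; others in the source may bear on it.

Values in an in vitro ADME assay on microsomes from liver (Homo sapiens) for metabolic stability, tested at 1 mg/mL (a lower number here means that the compound disappears faster, a higher number that the compound lasts longer), so far
Compound 1 `O=C(Nc1cc2cc[nH]c(=O)c2cc1Cl)[C@H]1CCCN1` with 0.283 h
Compound 2 `CN1CCC(C(=O)Nc2cc3cc[nH]c(=O)c3cc2Cl)CC1` with > 5 h

Compound 2 stands at > 5 h which is a limit and not a number.

In compound 3 `N[C@H]1CC[C@@H](C(=O)Nc2cc3cc[nH]c(=O)c3cc2Cl)CC1` 4-aminocyclohexyl takes the place of 1-methylpiperidin-4-yl on a carbonyl carbon (4-aminocyclohexyl in place of 1-methylpiperidin-4-yl on a carbonyl carbon) with the same atoms joined differently. Going by the values given here, the one measured step at such a carbonyl carbon (an at least 17-fold higher number from compound 1 to compound 2 (1.24 log units; beyond the scatter)) was large and shows that a change there can move the half-life far. A moderate fall in this assay is therefore expected, and the estimated step is (an at least 1.4-fold lower number from compound 2 to compound 3 (0.15 log units; that floor lies within the scatter)) in size. The estimate for compound 3 is 3.5 h with an expected range from 0.8 h to 10 h in all.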

Compound 3, half-life: 1.17 h
For compound 3 the middle estimate is 3.0-fold (0.48 log units) above the measured one, within the range that was stated.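

With the same atoms joined differently, 4-aminocyclohexyl gives an at least 4.2-fold lower number from compound 2 to compound 3 (0.63 log units; beyond the scatter) in this assay, so the arrangement of these atoms on the carbonyl carbon matters, not only their number. Set against pyrrolidin-2-yl, the same group gives a 4.1-fold higher number from compound 1 to compound 3 (0.62 log units; beyond the scatter), which places compound 3 between the other two compounds. Compound 2 stands at a limit, so its step to compound 3 is only a floor: the limit of > 5 h in this assay, at which 1 of the 3 values shown sits. The compounds shown leave open how a piperidin-4-yl group without the methyl, or a 4-hydroxycyclohexyl group, would fare on this carbonyl carbon.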